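Chloro to methoxy in a tolerated-concentration series

A few compounds are considered here, and "the series" means these few. Any claim that something is new, unique, unknown or untested is made for them only; others in the source may bear on it.

Measured so far in a toxicity assay on THP-1 cells (Homo sapiens) for inhibition; a higher number here means that more compound is tolerated, a lower number that less compound is tolerated:
- compound 1 `COc1ccc(-c2cnc(NC(=O)c3cccc([N+](=O)[O-])c3)n2C)cc1` gives > 100000 nM (a limit)
- compound 2 `COc1ccc(-c2cnc(NC(=O)c3cccc(Cl)c3)n2C)cc1` gives > 28000 nM (a limit)

Compound 2 stands at > 28000 nM and this is a limit of the assay, not a number. Compound 1 likewise gives only a limit, > 100000 nM with no number behind it.

The next entry is compound 3 `COc1ccc(-c2cnc(NC(=O)c3cccc(OC)c3)n2C)cc1`, which carries methoxy in place of chloro on an aromatic carbon, meta to a large group (methoxy in place of chloro on an aromatic carbon). Within the data shown here, the only measured step touching this position reads a step that the two limits leave unreadable from compound 1 to compound 2 and so supplies no size to carry forward. The data therefore give no direction for the change, and no step beyond the scatter is expected in this assay for this replacement. The expected change is a step that the limit leaves unreadable from compound 2 to compound 3 as an estimate, with no weight placed on its sign. For compound 3 the estimated value is 40000 nM with an expected range from 15000 nM to 100000 nM and the assay may well report only a limit again.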

Compound 3, half-maximal cytotoxic concentration: > 100000 nM
Compound 3 ended at the assay's limit; the forecaster's own chance of this, stated with the estimate: 80%; middle value at least 2.5-fold (0.39 log units) from the limit.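

In this assay compound 3 gives > 100000 nM, which is a limit of the assay and not a number. Among these compounds, no step among compound 1, compound 2 and compound 3 can be read, since all three values are limits. The compounds shown leave open whether nitro, chloro or methoxy on this aromatic carbon makes any difference in this assay.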